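Methyl for chloro on the fused ring in two sulfonyl analogues

The source may hold more compounds than are shown below. What is called first, only, known or untested is meant among the compounds shown, and "the series" means these compounds.

Among the measured compounds shown here, the series so far holds two measured compounds. Compound 1 `Cc1ccc2ncc(S(=O)(=O)c3cccc(Cl)c3)c(N3CCC(C)CC3)c2c1` gives, in an assay on isolated protein for displacement of a labelled ligand from metabotropic glutamate receptor 5 (Homo sapiens), with a stated time of 60 min, tested at 1 uM (a higher number here means more inhibition at the concentration tested (going by the name of the read-out), a lower number less inhibition), a reading of 91%. Compound 2 `COc1cccc(S(=O)(=O)c2cnc3ccc(Cl)cc3c2N2CCC(C)CC2)c1` gives in this assay 87%. Compound 2 stands within the scatter of compound 1; the two numbers do not separate, so neither compound can be set apart from the other on this assay.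

Compound 3 `COc1cccc(S(=O)(=O)c2cnc3ccc(C)cc3c2N2CCC(C)CC2)c1` is not yet measured. It differs from compound 2 in one place: methyl in place of chloro on an aromatic carbon. The same methyl on the fused ring is present in compound 1, which gives 91% in this assay, so the exchange offers no sign of a large shift.

The step from compound 2 to compound 3 is expected to be a number 1 percentage points higher from compound 2 to compound 3 (within the scatter), that is, none beyond the scatter. Compound 3 is therefore estimated to give 88% in this assay, with a range from 78% to 96%.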

Compound 3, a percentage reported as inhibition, at one concentration (the size of the read-out at that concentration, not a potency): 96%
Compound 3: middle estimate off by 8 percentage points, on the low side; measured number inside the range.
By their numbers in this assay, from the lowest: compounds 2, 1 and 3 (each within the scatter of the next).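

In this assay, methyl in place of chloro on this aromatic carbon gives (a number 9 percentage points higher from compound 2 to compound 3 (within the scatter)), so with the rest of compound 2 unchanged the two groups do not separate at this position. With methyl kept on the fused ring, a methoxy group taking the place of chloro on the other ring gives (a number 5 percentage points higher from compound 1 to compound 3 (within the scatter)), so this second single exchange does not separate either. Nothing measured here explains these readings.

The compounds shown leave open whether this position accepts a group of another kind, such as a carboxylic acid or an amine, in place of methyl or chloro. Going by these compounds, each reading is the size of the inhibition at one concentration, so whether compound 1, compound 2 and compound 3 would differ at other concentrations remains open.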